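Phenyl in place of chloro: an untested step in efficacy

The source may hold more compounds than are shown below. What is called first, only, known or untested is meant among the compounds shown, and "the series" means these compounds.

Of the compounds shown here, three built on one shared core have been measured in an in vitro functional assay on SH-SY5Y cells for agonist activity at Neuronal acetylcholine receptor; alpha3/beta4 (Homo sapiens), read by FLIPR and calcium flux; a lower number here means a smaller maximal response, a higher number a larger maximal response. Compound 1 `Clc1ccc(C2=CC3CNCC(C2)C3)cn1` gives 141%, the highest of the three numbers. Compound 2 `C1=C(c2cccnc2)C[C@@H]2CNC[C@H]1C2` gives 139%, a value within the usual scatter of the value of compound 1, so the two cannot be separated. Compound 3 `CN1CC2C=C(c3ccc(F)nc3)CC(C2)C1` gives 25%, which lies far below compound 1, well beyond the scatter.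

Compound 4 `C1=C(c2ccc(-c3ccccc3)nc2)CC2CNCC1C2` is not yet measured. It differs from compound 1 in one place: phenyl in place of chloro on an aromatic carbon. Going by the values given here, no pair of measured compounds differs by a comparable exchange, so there is no measured step to lean on. The change itself is large by count, one heavy atom leaving and six entering, larger than any difference among the measured compounds, and that leaves the expectation uncertain.

The step of a number 51 percentage points lower from compound 1 to compound 4 (beyond the scatter) is expected to be a decrease that goes beyond the scatter, though a result close to compound 1 cannot be excluded. Compound 4 is therefore estimated to reach 90% in this assay, with a likely range from 40% to 140%.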

Compound 4, largest response reached (reported as percent of maximum), in percent of the reference or control that the assay uses: 17%
The estimate for compound 4 lay 73 percentage points above the measured number, outside the stated range (below it).
By their numbers in this assay, from the lowest: compounds 4 and 3 (each within the scatter of the next); then compounds 2 and 1 (each within the scatter of the next).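

In this assay, placing phenyl instead of chloro on the aromatic carbon next to the ring nitrogen gives a number 124 percentage points lower from compound 1 to compound 4 (beyond the scatter), the first measured change at this position among the compounds shown. The shared core stays the same in this pair, so the fall in maximal response goes with this single exchange: compound 1 gives 141% and compound 4 gives only 17% in this assay. This shows that the position is not indifferent to what sits on it, since chloro is compatible with a large response and phenyl is not, yet no measurement shown explains the loss.

With only these two groups compared at this position, the compounds shown leave open how much of the response would remain with something of intermediate size, such as a methyl, a methoxy or a cyclopropyl group. They also leave open whether the aromatic character of the new ring matters, which a cyclohexyl group at the same position could test, and whether a pyridine ring in place of the phenyl would give a different result.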